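One More Carbon on the Side Chain

This account rests on a few compounds, and the source may have more. Where it says the series, first, only, none or still open, it means among the compounds named here.

Within the data shown here, in a functional assay on A549 cells (Homo sapiens) for antiproliferative activity, read by MTT assay, with a stated time of 72 h (on this read-out lower numbers stand for stronger inhibition and higher numbers for weaker inhibition), compound 1 `C/C=C/C(=O)Nc1cc2c(N3CCc4ccccc43)ncnc2cc1OC` gives 8290 nM and compound 2 `CC/C=C/C(=O)Nc1cc2c(N3CCc4ccccc43)ncnc2cc1OC` gives 2470 nM as the lowest number so far. The change to compound 3 `CCC/C=C/C(=O)Nc1cc2c(N3CCc4ccccc43)ncnc2cc1OC` is methyl in place of hydrogen on a saturated chain carbon, two bonds along the chain from a double-bonded chain carbon with methyl in place of hydrogen on a saturated chain carbon, two bonds along the chain from a double-bonded chain carbon. Among the measured compounds shown here, only one measured step bears on this: a 3.4-fold lower number from compound 1 to compound 2 (0.53 log units; beyond the scatter) is modest and of a similar kind. A single step sets no trend, but a smaller step in the same downward direction is expected, a 1.6-fold lower number from compound 2 to compound 3 (0.22 log units; within the scatter) by this estimate. The estimate expected for compound 3 is 1500 nM with 600 nM to 4500 nM as its range.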

Compound 3, half-maximal inhibitory concentration: 2920 nM
Beside the measured number, compound 3's estimate is 1.9-fold (0.29 log units) below it; the range from low to high includes it.
By their numbers in this assay, from the lowest: compounds 2 and 3 (each within the scatter of the next); then compound 1.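

Adding one more carbon does not carry the earlier drop further: a 1.2-fold higher number from compound 2 to compound 3 (0.07 log units; within the scatter) in this assay, so the two chains cannot be told apart. The longer chain still keeps a gain over the shortest one, with a 2.8-fold lower number from compound 1 to compound 3 (0.45 log units; beyond the scatter), which suggests a level stretch among these three compounds rather than a steady trend. Nothing measured here offers a reason for this levelling. Still open, going by these compounds, is whether a longer chain would stay at this level, and whether an amine in place of the added methyl would move the number beyond the scatter.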